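Lengthening the Sulfonamide Chain of Compound 2

The source may report more compounds than this note shows. Statements on the series, on what has been measured and on what is new or still open speak of the compounds shown alone.

Of the compounds shown here, three that share a core have been measured so far. Compound 1 (`CN(C)S(=O)(=O)c1ccc(F)c(C#Cc2cc(Cl)ccc2OCC(=O)O)c1`) gives < 10 mL.min-1.g-1 in an in vitro ADME assay on microsomes from liver (Rattus norvegicus) for metabolic stability, read by LC-MS, tested at 1 uM (a lower number here means slower removal, a higher number faster removal of the compound), and this is a limit of the assay and not a number. Compound 2 (`Cc1ccc(S(=O)(=O)N(C)C(C)C)cc1C#Cc1cc(Cl)ccc1OCC(=O)O`) gives 64 mL.min-1.g-1 in this assay and compound 3 (`Cc1ccc(S(=O)(=O)NC(C)C)cc1C#Cc1cc(Cl)ccc1OCC(=O)O`) gives 12 mL.min-1.g-1 in the same test. Compound 2 therefore holds the higher of the two true numbers, which means it is removed faster than compound 3.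

Compound 4 (`Cc1ccc(S(=O)(=O)N(C)CC(C)C)cc1C#Cc1cc(Cl)ccc1OCC(=O)O`) has not yet been measured. It carries isobutyl in place of isopropyl on a sulfonamide nitrogen of compound 2 (isobutyl in place of isopropyl on a sulfonamide nitrogen). Among the compounds with values here, no measured step makes this exact change. Within the data shown here, the only step at that nitrogen is a different one, hydrogen in place of methyl, and it gives a modest drop of a 5.3-fold lower number from compound 2 to compound 3 (0.73 log units; beyond the scatter) that lies beyond the scatter. Compound 4 keeps that methyl, so a drop of this kind is not expected, and its number should stay close to that of compound 2. The expected change is small, an estimated 1.3-fold higher number from compound 2 to compound 4 (0.10 log units; within the scatter) and so probably within the scatter. For compound 4 the estimated value is 80 mL.min-1.g-1 (expected range 35 mL.min-1.g-1 to 180 mL.min-1.g-1) in this assay.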

Compound 4, intrinsic clearance in microsomes: 119 mL.min-1.g-1
Compound 4: the middle estimate sits 1.5-fold (0.17 log units) below what was measured; low and high end bracket the measured number.
By their numbers in this assay, from the lowest: compound 3; then compounds 2 and 4 (each within the scatter of the next). At a limit, below all of these: compound 1.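

In this assay, isobutyl in place of isopropyl on the sulfonamide nitrogen, with the methyl kept, gives a 1.9-fold higher number from compound 2 to compound 4 (0.27 log units; within the scatter), so the extra carbon of isobutyl makes no clear difference between these two compounds. The large gap appears only when the whole group on the sulfonyl sulfur differs, as in a 9.9-fold higher number from compound 3 to compound 4 (1.00 log units; beyond the scatter), and that step combines the exchange of isopropyl for isobutyl with that of hydrogen for methyl, so it cannot credit either exchange alone. Nothing measured here gives a reason for the size of either step.

The compounds shown leave open what isobutylamino, which has hydrogen in place of the methyl on the same nitrogen, would give, and that comparison would pull the two exchanges inside the larger step apart. They also leave open whether the number stays in the same range with a longer chain such as n-pentyl, or changes with a chain that ends in a hydroxyl group or an amine.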